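From compound 3 to compound 4: replacing dimethylamino

A few compounds are considered here, and "the series" means these few. Any claim that something is new, unique, unknown or untested is made for them only; others in the source may bear on it.

Measured so far in an ADME assay on microsomes from liver (Mus musculus, strain CD-1) for metabolic stability, read by LC-MS, tested at 2 uM; a lower number here means that the compound disappears faster, a higher number that the compound lasts longer
compound 1 `Cn1ccc2ccc(-c3cc(Nc4ccccc4S(N)(=O)=O)cc4nccnc34)cc21` gives 0.5 h
compound 2 `CNS(=O)(=O)c1ccccc1Nc1cc(-c2ccc3ccn(C)c3c2)c2nccnc2c1` gives 0.2 h
compound 3 `CN(C)C(=O)c1ccncc1Nc1cc(-c2ccc3ccn(C)c3c2)c2nccnc2c1` gives 0.35 h

In this assay compound 3 gives 0.35 h and so lies within the scatter of both compound 1 and compound 2, the compounds at the two ends of this small set. Compound 4 `CN1CCC(NC(=O)c2ccncc2Nc2cc(-c3ccc4ccn(C)c4c3)c3nccnc3c2)CC1` keeps the shared core and carries (1-methylpiperidin-4-yl)amino in place of dimethylamino on a carbonyl carbon.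

Among the measured compounds shown here, the only measured step in the set is modest and beyond the scatter (a 2.5-fold lower number from compound 1 to compound 2 (0.40 log units; beyond the scatter)). It is methyl in place of hydrogen on a sulfonamide nitrogen, a different place from the carbonyl carbon changed here. For the measured compounds named here, no measured step touches that carbonyl carbon, so the data offer only an indirect guide to this exchange. With compound 3 (0.35 h) as the starting point, no shift beyond the scatter is expected in this assay, and the direction remains uncertain. The estimated change is small (a 1.2-fold lower number from compound 3 to compound 4 (0.07 log units; within the scatter)). Compound 4 is expected at 0.3 h with 0.12 h to 0.7 h as the estimated range.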

Compound 4, half-life: > 1 h
Compound 4 ended at the assay's limit (the forecaster's own chance of this, stated with the estimate: 3%); middle value at least 3.3-fold (0.52 log units) away from the limit.
By their numbers in this assay, from the lowest: compounds 2, 3 and 1 (each within the scatter of the next, the first and the last beyond it). At a limit, above all of these: compound 4.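

In this assay compound 4 gives > 1 h, which is a limit of the assay and not a number: the limit of > 1 h in this assay, at which 1 of the 4 values shown sits.

Going by these compounds, the exchange of dimethylamino for (1-methylpiperidin-4-yl)amino on a carbonyl carbon gives an at least 2.8-fold higher number from compound 3 to compound 4 (0.45 log units; beyond the scatter), so this position can shift the half-life beyond the scatter, and the true size of the shift remains unknown at the limit. Among the compounds shown here, the earlier step, a 2.5-fold lower number from compound 1 to compound 2 (0.40 log units; beyond the scatter), concerned a sulfonamide nitrogen and went the other way, so the new step is the first in this set to raise the number, and the first to show that the carbonyl carbon is a place where this assay responds to change.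

The compounds shown leave open which part of the entering group goes with the step, since the six-membered ring, its methyl and the amide hydrogen all enter together. Whether a simple methylamino, a cyclohexylamino or a piperidin-4-ylamino without the methyl on the carbonyl carbon would give a similar half-life is not answered by these compounds, and neither is the effect of the same group on other cores.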